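A few compounds are considered here, and "the series" means these few. Any claim that something is new, unique, unknown or untested is made for them only; others in the source may bear on it.

Of the compounds shown here, two have been measured in a functional assay on NCI-H1975 cells (Homo sapiens) for antiproliferative activity, read by CCK-8 assay, with a stated time of 72 h; a lower number here means a stronger inhibitor of growth, a higher number a weaker inhibitor of growth. Compound 1, `CCC1C(=O)N(C)c2cnc(Nc3ccc(S(=O)(=O)NCCCO)cc3)nc2N1c1ccn(C)n1`, gives 25800 nM in that assay. Compound 2, `CCC1C(=O)N(C)c2cnc(-n3ccc4cc(C(=O)NCC(C)C)ccc43)nc2N1c1ccn(C)n1`, gives 10200 nM in this assay. On these two numbers compound 1 stands highest, and the gap to compound 2 lies beyond the usual scatter of repeated measurements, so compound 1 is the weaker inhibitor of growth of the pair that has been tested.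

Compound 3, `CCC1C(=O)N(C)c2cnc(Nc3ccc(S(N)(=O)=O)cc3)nc2N1c1ccn(C)n1`, has not yet been measured in this assay. It differs from compound 1 in a single place: hydrogen in place of 3-hydroxypropyl on a sulfonamide nitrogen. The shared core, the substituents on it and the rest of the aryl sulfonamide arm are unchanged; only the group on the sulfonamide nitrogen is trimmed back to hydrogen.

Among the measured compounds shown here, no measured pair in this set shows what such a change does, so the expectation rests on compound 1 alone. The step of a 1.3-fold lower number from compound 1 to compound 3 (0.11 log units; within the scatter) is expected to be small, close to or within the scatter, with no strong direction either way. Compound 3 is therefore estimated at 20000 nM in this assay, with a plausible range from 7000 nM to 60000 nM.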

Compound 3, concentration for 50% growth inhibition: "not active" (no number reported)
Compound 3: no number reported, and the estimate cannot be compared.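

In this assay, among the compounds shown here, compound 3 is recorded as not active, with no number reported, so no step from compound 1 to compound 3 can be read. Nothing in the available evidence bears on this result. The compounds shown leave open how far compound 1 at 25800 nM stands from compound 3 in growth inhibition.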